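Amine side chain variation in the measured series

The compounds below may be only part of what the source reports. "The series", "measured", "known", "first", "only" and "open" are said of these compounds alone.

compound 1 `CCN(CC)CCCOc1c(-c2cc(OC)c(OC)c(OC)c2)oc2ccccc2c1=O` — > 50000 nM
compound 2 `CCN(CC)CCCCOc1c(-c2cc(OC)c(OC)c(OC)c2)oc2ccccc2c1=O` — 13300 nM
compound 3 `CCCCN(CCCC)CCCCCOc1c(-c2cc(OC)c(OC)c(OC)c2)oc2ccccc2c1=O` — to be measured

Among the measured compounds shown here, in a functional assay on DU-145 cells (Homo sapiens) for antiproliferative activity, read by WST assay, with a stated time of 3 days (on this read-out higher numbers stand for weaker inhibition and lower numbers for stronger inhibition), compound 2 gives 13300 nM, the only number in the set. Compound 1 returns > 50000 nM, which is a limit of the assay and not a number. Compound 2 therefore stands alone among the numbers, with the other value sitting at the limit (the limit of > 50000 nM in this assay, at which 1 of the 2 values shown sits). For the measured compounds named here, the one measured step, an at least 3.7-fold lower number from compound 1 to compound 2 (0.57 log units; beyond the scatter), runs toward stronger inhibition and is at least modest, lying beyond the scatter; because of the limit of > 50000 nM in this assay, at which 1 of the 2 values shown sits, its full size is not fixed. Compound 3 differs from compound 2 by (dibutylamino)methyl in place of diethylamino on a saturated chain carbon, four bonds along the chain from an oxygen on an aromatic ring. This continues the chain lengthening seen in the measured step and brings in the larger amine, so a further step toward stronger inhibition is expected, of roughly the same order, a 3.3-fold lower number from compound 2 to compound 3 (0.52 log units; beyond the scatter). Compound 3 is estimated at 4000 nM, within a range of 1000 nM to 15000 nM.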

Compound 3, half-maximal inhibitory concentration: > 50000 nM
Compound 3 was reported as a limit (the forecaster's own chance of this, stated with the estimate: 5%); middle value at least 12-fold (1.09 log units) away from the limit.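

In this assay, placing (dibutylamino)methyl on this saturated chain carbon, four bonds along the chain from an oxygen on an aromatic ring, gives an at least 3.7-fold higher number from compound 2 to compound 3 (0.57 log units; beyond the scatter), so the gain seen in the earlier step does not continue with this change. Compound 3 gives > 50000 nM, which is a limit of the assay and not a number. Compound 2 remains the only one of the three with a number, and neither the full size of the steps to it nor the step between the other two compounds can be read: the limit of > 50000 nM in this assay, at which 2 of the 3 values shown sit.

The butyl groups on the nitrogen and the added chain length change together in this step, and the compounds shown do not separate them. From the compounds shown here alone, how diethylamino reads on the chain of compound 3, or a cyclic amine such as piperidine or morpholine on the chain of compound 2, stays open.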